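A trifluoromethyl exchange at the assay limit

This account rests on a few compounds, and the source may have more. Where it says the series, first, only, none or still open, it means among the compounds named here.

- compound 1 `Nc1nc2cc(Cl)c(Cl)cc2n1Cc1ccc(Cl)cc1`: 32000 nM
- compound 2 `Clc1ccc(Cn2c(Cl)nc3cc(Cl)c(Cl)cc32)cc1`: > 100000 nM
- compound 3 `Clc1ccc(Cn2c(Cl)nc3cc(Cl)c(Cl)cc32)cc1Cl`: > 100000 nM

In a functional assay on CEM-SS cells (Homo sapiens) for cytotoxicity (on this read-out lower numbers stand for stronger inhibition and higher numbers for weaker inhibition), compound 1 gives a true number, 32000 nM. From the compounds shown here alone, compound 2 gives only a limit, > 100000 nM, so its exact value is unknown. Compound 3 likewise gives only a limit, > 100000 nM. Together these two results make up (the limit of > 100000 nM in this assay, at which 2 of the 3 values shown sit).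

The unmeasured compound 4 `FC(F)(F)c1ccc(Cn2c(Cl)nc3cc(Cl)c(Cl)cc32)cc1` carries trifluoromethyl in place of chloro on an aromatic carbon, para to a large group: trifluoromethyl in place of chloro on an aromatic carbon.

Going by the values given here, two measured steps bear on this change. Chloro in place of hydrogen on an aromatic carbon gave a step that the two limits leave unreadable from compound 2 to compound 3. Chloro in place of amino on an aromatic carbon gave an at least 3.1-fold higher number from compound 1 to compound 2 (0.49 log units; beyond the scatter), but that is a different exchange. Neither step points to a clear shift for compound 4, so no step beyond the scatter is expected in this assay, and another limit is likely. The expected change is a number no higher from compound 2 to compound 4 (the limit leaves the size open). For compound 4 the estimated value is 100000 nM, with an expected range from 40000 nM to 250000 nM.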

Compound 4, half-maximal inhibitory concentration: > 100000 nM
Compound 4: only a limit was reported; the forecaster's own chance of this, stated with the estimate: 70%; the middle value lies on the limit itself.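

In this assay compound 4 gives only a limit, > 100000 nM, and compound 2 is also held at a limit, so no step from compound 2 to compound 4 can be read: the limit of > 100000 nM in this assay, at which 3 of the 4 values shown sit.

The compounds shown leave open whether compound 2, compound 3 and compound 4 truly differ in this assay.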